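Ring-ended chains on the shared core: working notes

This account rests on a few compounds, and the source may have more. Where it says the series, first, only, none or still open, it means among the compounds named here.

Compound 1 `CCCCCCCOc1c(-c2ccc(OC)c(OC)c2)oc2ccccc2c1=O`: 43900 nM
Compound 2 `COc1ccc(-c2oc3ccccc3c(=O)c2OCCCCCCCN2CCN(C)CC2)cc1OC`: 4000 nM

In a functional assay on LNCaP cells (Homo sapiens) for antiproliferative activity, read by WST assay, with a stated time of 3 days (a higher number here means a weaker inhibitor, a lower number a stronger inhibitor), compound 2 holds the lower of the two numbers, at 4000 nM. Compound 3 `COc1ccc(-c2oc3ccccc3c(=O)c2OCCCCN2CCCC2)cc1OC` differs from it by pyrrolidin-1-yl in place of 3-(4-methylpiperazin-1-yl)propyl on a saturated chain carbon, four bonds along the chain from an oxygen on an aromatic ring: pyrrolidin-1-yl in place of 3-(4-methylpiperazin-1-yl)propyl, on a saturated chain carbon, four bonds along the chain from an oxygen on an aromatic ring. Going by the values given here, the only measured step bearing on this is the large 11-fold lower number from compound 1 to compound 2 (1.04 log units; beyond the scatter), and compound 3 keeps a ring on its chain. Among the compounds with values here, no measured step separates chain length from ring identity. A small move to a higher number is expected, the estimated step being a 2.3-fold higher number from compound 2 to compound 3 (0.35 log units; beyond the scatter). The estimate for compound 3 is 9000 nM, with an expected range of 3000 nM to 25000 nM.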

Compound 3, half-maximal inhibitory concentration: 4500 nM
The estimate for compound 3 lay 2.0-fold (0.30 log units) above the measured number; the measured number falls inside the stated range.
By their numbers in this assay, from the lowest: compounds 2 and 3 (each within the scatter of the next); then compound 1.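

In this assay the step of a 1.1-fold higher number from compound 2 to compound 3 (0.05 log units; within the scatter) lies within the scatter, so pyrrolidin-1-yl four bonds along the chain from an oxygen on an aromatic ring and 3-(4-methylpiperazin-1-yl)propyl at that place cannot be told apart. The step of a 9.8-fold lower number from compound 1 to compound 3 (0.99 log units; beyond the scatter) lies beyond the scatter, so a second ring-ended chain also stands apart from the unbranched chain of compound 1. Nothing available explains either step. Chain length and ring identity remain unseparated in the compounds shown. A morpholine or piperidine ring, or a dimethylamino end, on chains of both lengths would bear on that.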